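Ethoxycarbonyl in place of aryl ketone on the fused core

A few compounds are considered here, and "the series" means these few. Any claim that something is new, unique, unknown or untested is made for them only; others in the source may bear on it.

Measured compounds in the series:
Compound 1, `COc1cc(-c2nnc(SCc3ccccc3)n2/N=C/c2ccccc2)cc(OC)c1OC`: in a functional assay on HT-29 cells (Homo sapiens) for cytotoxicity, read by MTT assay, with a stated time of 48 h (on this read-out lower numbers stand for stronger inhibition and higher numbers for weaker inhibition), compound 1 gives > 200000 nM, which is a limit of the assay and not a number.
Compound 2, `COc1cc(-c2nnc(SCc3ccc(F)cc3)n2/N=C/c2ccccc2)cc(OC)c1OC`: in this assay compound 2 gives > 200000 nM, again a limit rather than a number.
Compound 3, `COc1cc(-c2nnc3n2NC(CC(=O)c2ccc(C)cc2)(c2ccccc2)S3)cc(OC)c1OC`: in this assay compound 3 gives 151000 nM.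

Within the data shown here, compound 3 thus stands as the only numerical value; the two remaining values sit at the limit of > 200000 nM in this assay, at which 2 of the 3 values shown sit. Among the measured compounds shown here, the single measured step, a step that the two limits leave unreadable from compound 1 to compound 2, is a comparison of two limits and cannot be read, and it concerns a different change on a different pair of structures, so no measured step bears on the change considered here.

Compound 4, `CCOC(=O)CC1(c2ccccc2)Nn2c(nnc2-c2cc(OC)c(OC)c(OC)c2)S1`, differs from compound 3 in one place: ethoxy in place of 4-methylphenyl on a carbonyl carbon.

With no readable step available, the expectation rests only on where compound 3 stands. The change is expected to give no step beyond the scatter, a 1.3-fold higher number from compound 3 to compound 4 (0.12 log units; within the scatter), with some chance that this assay returns only a limit. Compound 4 is therefore estimated at 200000 nM, within a range from 60000 nM to 600000 nM.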

Compound 4, half-maximal inhibitory concentration: > 200000 nM
Compound 4 was reported as a limit; the forecaster's own chance of this, stated with the estimate: 50%; the middle value sits exactly at the limit.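

In this assay, on these data alone, ethoxy on the carbonyl carbon in place of 4-methylphenyl gives an at least 1.3-fold higher number from compound 3 to compound 4 (0.12 log units; that floor lies within the scatter); this is only a floor, so the true size of the step stays unknown and the step cannot be placed relative to the usual scatter. The value of compound 4, > 200000 nM, is a limit of the assay and not a number. Of the two groups seen at this place, only (4-methylphenyl)carbonyl gives a readable number, and the ethoxycarbonyl of compound 4 joins the other compounds at the limit: the limit of > 200000 nM in this assay, at which 3 of the 4 values shown sit.

The compounds shown leave open whether the readable value of compound 3 depends on the aromatic ring of 4-methylphenyl or on the ketone carbonyl, a question that a plain phenyl or a methyl on the same carbonyl carbon, or a carboxylic acid or an amide in place of the ester, could address. They also leave open whether any group at this place can bring the number far under that of compound 3 in this assay.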